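The compounds below may be only part of what the source reports. "The series", "measured", "known", "first", "only" and "open" are said of these compounds alone.

In a functional assay on the whole organism for positive allosteric modulation, with Mus musculus as the target (a lower number here means that less compound is needed, a higher number that more compound is needed for the effect), compound 1 `CCCC(=O)N(c1ccccc1)C1CCCC1N(C)C` gives 40 mg/kg, and compound 2 `CCC(=O)N(c1cccc(C(F)(F)F)c1)C1CCCC1N(C)C` gives 0.9 mg/kg. Compound 3 `CCCN(CCC)C1CCCC1N(C(=O)CC)c1ccc(Cl)c(Cl)c1` gives > 50 mg/kg, which is a limit of the assay and not a number. Of the three measured compounds, only compound 3 stands at the limit of > 50 mg/kg in this assay, at which 1 of the 3 values shown sits. Compound 4 `CCC(=O)N(c1ccc(Cl)c(Cl)c1)C1CCCC1N(C)CCN(C)C` differs from compound 3 by (2-(dimethylamino)ethyl)(methyl)amino in place of dipropylamino on a saturated ring carbon, with (2-(dimethylamino)ethyl)(methyl)amino in place of dipropylamino on a saturated ring carbon. Going by the values given here, no measured pair shows this change alone, so a moderate step toward a lower dose in this assay is only an expectation. That expectation leans on compound 1 at 40 mg/kg, a measured value at the high end of the doses seen. The expected change is an at least 2.0-fold lower number from compound 3 to compound 4 (0.30 log units; that floor lies within the scatter). For compound 4 the estimate is 25 mg/kg, with an expected range of 5 mg/kg to 80 mg/kg.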

Compound 4, dose for half-maximal effect: 20 mg/kg
For compound 4 the middle estimate is 1.3-fold (0.10 log units) above the measured one; measured number inside the range.
By their numbers in this assay, from the lowest: compound 2; then compounds 4 and 1 (each within the scatter of the next). At a limit, above all of these: compound 3.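

On the saturated ring carbon, (2-(dimethylamino)ethyl)(methyl)amino in place of dipropylamino gives an at least 2.5-fold lower number from compound 3 to compound 4 (0.39 log units; beyond the scatter) in this assay. This is the first change among the compounds shown that can be read at this position alone, and it shows that the group here affects the dose. The value of compound 3 is a limit and not a number, so the true size of the step is unknown: the limit of > 50 mg/kg in this assay, at which 1 of the 4 values shown sits.

The compounds shown do not separate the effect of the second nitrogen from that of the chain. From the compounds shown here alone, how a pyrrolidine or a chain ending in a hydroxyl group would read at this position stays open.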